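This account rests on a few compounds, and the source may have more. Where it says the series, first, only, none or still open, it means among the compounds named here.

Measured so far in an assay on CHO cells for displacement of a labelled ligand from adenosine receptor A3 (Homo sapiens), read by scintillation counting, tested at 10 uM; on this read-out lower numbers stand for less inhibition and higher numbers for more inhibition at the one concentration tested (going by the name of the read-out):

compound 1 `CC(C)(C)Cc1c(-c2ccc(F)cc2)sc(N)c1C(=O)c1ccc(Cl)cc1` gives 9%
compound 2 `CC(C)(C)Cc1csc(N)c1C(=O)c1ccc(Cl)c(Cl)c1` gives 10%

Both measured compounds sit at low inhibition in this assay. Going by the values given here, compound 1 has the lower of the two numbers, but its gap to compound 2 lies within the usual scatter, so the two cannot be ordered; no step between measured compounds is available from which to read a trend.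

Compound 3 `CC(C)(C)Cc1c(-c2cn[nH]c2)sc(N)c1C(=O)c1ccc(Cl)cc1` is not yet measured. It differs from compound 1 in one place: 1H-pyrazol-4-yl in place of 4-fluorophenyl on an aromatic carbon. Among the compounds with values here, nothing among the measured compounds shows how a change of this kind moves the read-out, and the only comparison at hand, compound 1 against compound 2, stays flat. The working expectation is therefore a step from compound 1 to compound 3 of about a number 3 percentage points higher from compound 1 to compound 3 (within the scatter) in this assay, which is not expected to exceed the scatter. Compound 3 is accordingly estimated at 12% in this assay, within a range from 0% to 30%.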

Compound 3, a percentage reported as inhibition, at one concentration (the size of the read-out at that concentration, not a potency): 1%
Estimate against measurement, compound 3: 11 percentage points above; low and high end bracket the measured number.
By their numbers in this assay, from the lowest: compounds 3, 1 and 2 (each within the scatter of the next).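

In this assay, this position, on an aromatic carbon next to the ring sulfur, now has its first one-place comparison: 1H-pyrazol-4-yl in place of 4-fluorophenyl gives a number 8 percentage points lower from compound 1 to compound 3 (within the scatter). Replacing a six-membered carbon ring bearing fluorine with a five-membered ring carrying a hydrogen-bond donor and acceptor therefore produces no change that can be told from scatter, and compound 3 stays low at 1%. No available measurement offers an explanation for this result.

From the compounds shown here alone, it remains open whether a carboxylic acid or a dimethylamino group on this carbon would move the read-out out of the low range. Also open, going by these compounds, is whether replacing the neopentyl group with a longer chain would have any greater effect in this assay.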